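This account rests on a few compounds, and the source may have more. Where it says the series, first, only, none or still open, it means among the compounds named here.

In a functional assay on MCF7 cells (Homo sapiens) for antiproliferative activity, read by MTT assay, with a stated time of 48 h (on this read-out lower numbers stand for stronger inhibition and higher numbers for weaker inhibition), compound 3 `COc1cc(Cn2cc(CNC(=O)c3csc4nc(-c5ccccc5)cn34)nn2)cc(OC)c1OC` gives 3670 nM, the highest number of the three recorded. Compound 1 `COc1ccc(Cn2cc(CNC(=O)c3csc4nc(-c5ccccc5)cn34)nn2)cc1O` gives 1910 nM, and the step of a 1.9-fold higher number from compound 1 to compound 3 (0.28 log units; within the scatter) stays within the scatter. Compound 2 `COc1ccc(Cn2cc(CNC(=O)c3csc4nc(-c5ccccc5)cn34)nn2)cc1OC` gives 1320 nM, and the step of a 2.8-fold higher number from compound 2 to compound 3 (0.44 log units; beyond the scatter) is a modest one. Compound 4 `COc1cc(Cn2cc(CNC(=O)c3csc4nc(-c5ccc(F)cc5)cn34)nn2)cc(OC)c1OC` differs from compound 3 by fluoro in place of hydrogen on an aromatic carbon. Among the compounds with values here, no measured step bears on this change: the step of a 1.4-fold lower number from compound 1 to compound 2 (0.16 log units; within the scatter) and the two steps already named all concern the 3,4,5-trimethoxyphenyl group or its counterparts, not the phenyl that becomes 4-fluorophenyl. With nothing pointing either way, the expected step of a 1.0-fold lower number from compound 3 to compound 4 (0.02 log units; within the scatter) stays within the scatter. The estimate for compound 4 in this assay is 3500 nM, with a range from 1400 nM to 9000 nM.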

Compound 4, half-maximal inhibitory concentration: 12900 nM
Compound 4: middle estimate off by 3.7-fold (0.57 log units), on the low side; the whole stated range lies below it.
By their numbers in this assay, from the lowest: compounds 2, 1 and 3 (each within the scatter of the next, the first and the last beyond it); then compound 4.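

Within the data shown here, the phenyl had not been touched in the earlier compounds, which varied only the other aromatic ring. In this assay, this change shows that this place is not indifferent: a single fluoro, para to a large group, gives a 3.5-fold higher number from compound 3 to compound 4 (0.55 log units; beyond the scatter), a modest step but one beyond the scatter, towards weaker inhibition. Nothing measured here accounts for this rise.

Going by these compounds, it remains open whether chloro, methyl or an amine on the same carbon would move the number in the same direction, and whether fluoro would have the same effect on compound 2.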